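Chloro for methyl on the aryl ring of compound 2

This account rests on a few compounds, and the source may have more. Where it says the series, first, only, none or still open, it means among the compounds named here.

Compound 1 `Nc1nc2ccnc(-c3cccc(Br)c3)n2n1`: 3700 nM; 3700 nM (2 entries)
Compound 2 `Cc1cccc(-c2nccc3nc(N)nn23)c1`: 5500 nM
Compound 3 `Nc1nc2ccnc(-c3cccc(OC(F)F)c3)n2n1`: 3400 nM; 3400 nM (2 entries)

Of the compounds shown here, three sharing one core have been measured in a functional assay (Homo sapiens); a lower number here means a stronger inhibitor, a higher number a weaker inhibitor. Compound 1 `Nc1nc2ccnc(-c3cccc(Br)c3)n2n1` gives 3700 nM; 3700 nM (2 entries) in this assay, compound 3 `Nc1nc2ccnc(-c3cccc(OC(F)F)c3)n2n1` gives 3400 nM; 3400 nM (2 entries), and the two values lie within the scatter of each other. Going by the values given here, compound 2 `Cc1cccc(-c2nccc3nc(N)nn23)c1` gives 5500 nM in this assay; that is the only full number it has, two further measurements of compound 2 in this assay carrying no single number. Set beside compound 1 and compound 3, compound 2 shows a somewhat higher number, though no step between these measured compounds has been computed.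

Compound 4 `Nc1nc2ccnc(-c3cccc(Cl)c3)n2n1` is not yet measured. It differs from compound 2 in one place: chloro in place of methyl on an aromatic carbon. Among the compounds with values here, no measured pair maps this exact change. The values of compound 1 and compound 3, both substituted on the same ring, sit a little lower than compound 2, so the author expects the step from compound 2 to compound 4 to be a modest one toward stronger inhibition, of a size near the edge of the scatter, estimated as a 1.4-fold lower number from compound 2 to compound 4 (0.16 log units; within the scatter). For compound 4 the author estimates 3800 nM in this assay, with a range from 1800 nM to 8000 nM.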

Compound 4, half-maximal inhibitory concentration: 4300 nM
Beside the measured number, compound 4's estimate is 1.1-fold (0.05 log units) below it, and the stated range covers the measured number.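

In this assay, going by these compounds alone, the change from methyl to chloro on this aromatic carbon gives a 1.3-fold lower number from compound 2 to compound 4 (0.11 log units; within the scatter), the first step at this position that can be read, and it shows that this exchange of one heavy atom for another does not move the number beyond the scatter. The chloro group also joins the bromo and difluoromethoxy groups in the same range of values: compound 4 gives 4300 nM while compound 1 gives 3700 nM; 3700 nM (2 entries) and compound 3 gives 3400 nM; 3400 nM (2 entries), so none of the three substituents on this ring stands apart from the others by its printed value. Nothing available here accounts for the size of this step.

The compounds shown leave open whether a group of a different kind at this position, such as an amine, a carboxylic acid or a longer chain, would shift the number beyond the scatter in either direction. They also leave open how a ring with only hydrogen at this carbon would compare with compound 2 and compound 4.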